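The compounds below may be only part of what the source reports. "The series", "measured", "known", "first", "only" and "open" are said of these compounds alone.

- compound 1 `COC(=O)C1=C(C)N=C(C)/C(=C(\O)OC)C1c1cc(Cl)cc(Cl)c1` with 93.3 nM
- compound 2 `CCOc1ccccc1C1C(C(=O)OC)=C(C)N=C(C)/C1=C(\O)OC` with 110 nM

In a functional assay (muscle tissue) with Cavia porcellus as the target (on this read-out higher numbers stand for an effect only at larger amounts of compound and lower numbers for an effect already at smaller amounts), compound 2 gives 110 nM and so lies within the scatter of compound 1 at 93.3 nM with no order between the two. Compound 3 `COC(=O)C1=C(C)N=C(C)/C(=C(\O)OC)C1c1ccccc1Br` differs from compound 2 at one place: bromo in place of ethoxy on an aromatic carbon with bromo in place of ethoxy on an aromatic carbon. Among the compounds with values here, no measured pair shows a comparable change, so the size of the step is a judgement. In this assay the expected step is a 7.3-fold lower number from compound 2 to compound 3 (0.87 log units; beyond the scatter) as an estimated move to a lower number, beyond the scatter. For compound 3 the estimated value is 15 nM with an expected range from 3 nM to 70 nM around it.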

Compound 3, half-maximal effective concentration: 7.59 nM
Beside the measured number, compound 3's estimate is 2.0-fold (0.30 log units) above it, within the range that was stated.
By their numbers in this assay, from the lowest: compound 3; then compounds 1 and 2 (each within the scatter of the next).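

In this assay bromo in place of ethoxy on an aromatic carbon gives a 14-fold lower number from compound 2 to compound 3 (1.16 log units; beyond the scatter) and 2-bromophenyl in place of 3,5-dichlorophenyl on a saturated ring carbon gives a 12-fold lower number from compound 1 to compound 3 (1.09 log units; beyond the scatter) on the same core. Within the data shown here, compound 1 and compound 2 had not separated, so these steps are the first to show that the read-out responds to the group carried here. Nothing measured here accounts for the size of these steps.

Still open, on these data alone, is whether fluoro, methyl or an amine on that aromatic carbon would give a number like that of compound 3. Also open, as far as these compounds go, is whether bromo would hold its effect at another carbon of the six-membered aromatic ring.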